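A few compounds are considered here, and "the series" means these few. Any claim that something is new, unique, unknown or untested is made for them only; others in the source may bear on it.

For the measured compounds named here, in a functional assay on MDA-MB-231 cells (Homo sapiens) for inhibition, with a stated time of 72 h (on this read-out higher numbers stand for weaker inhibition and lower numbers for stronger inhibition), compound 3 `Cc1ccc(NC(=O)Nc2nc(Nc3ccccc3)cc(Sc3c[nH]c4ccccc34)n2)cc1` gives 13400 nM, the second highest of the three numbers known so far. Compound 1 `O=C(Nc1ccccc1)Nc1nc(Nc2ccccc2)cc(Sc2c[nH]c3ccccc23)n1` gives 35900 nM, while compound 2 `COc1ccc(NC(=O)Nc2nc(Nc3cc(OC)cc(OC)c3)cc(Sc3c[nH]c4ccccc34)n2)cc1` gives 9460 nM, which sits within the scatter of compound 3. Compound 4 `Cc1cc(Cl)ccc1NC(=O)Nc1nc(Nc2ccccc2)cc(Sc2c[nH]c3ccccc23)n1` carries 4-chloro-2-methylphenyl in place of 4-methylphenyl on an amide-type nitrogen. Going by the values given here, the only measured step that bears on this change is a 2.7-fold lower number from compound 1 to compound 3 (0.43 log units; beyond the scatter), showing that a methyl on this ring shifts the number beyond the scatter. Among the compounds with values here, no measured pair shows what a chlorine adds, and compound 2 differs from compound 3 in two places, so its value cannot be read as a single step. The expected step of a 1.3-fold lower number from compound 3 to compound 4 (0.13 log units; within the scatter) is therefore small, in either direction. Compound 4 is estimated at 10000 nM, within a range from 3000 nM to 35000 nM.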

Compound 4, half-maximal inhibitory concentration: 17100 nM
For compound 4 the middle estimate is 1.7-fold (0.23 log units) below the measured one; the range from low to high includes it.
By their numbers in this assay, from the lowest: compounds 2, 3 and 4 (each within the scatter of the next); then compound 1.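

Replacing 4-methylphenyl with 4-chloro-2-methylphenyl on the amide-type nitrogen gives a 1.3-fold higher number from compound 3 to compound 4 (0.11 log units; within the scatter) in this assay and so leaves the number within the scatter. Set against the unsubstituted phenyl, the same group gives a 2.1-fold lower number from compound 1 to compound 4 (0.32 log units; beyond the scatter) and so stays beyond the scatter, as 4-methylphenyl does. No measurement shown offers a reason for these numbers. As far as these compounds go, what chlorine contributes on its own remains open, since the two groups differ in more than one feature. Also open, from the compounds shown here alone, is how an amine or a carboxylic acid on this ring would behave.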